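The compounds below may be only part of what the source reports. "The series", "measured", "known", "first", "only" and "open" are said of these compounds alone.

Measured compounds:
Compound 1 `CCn1c(CNc2ccccc2)nnc1SCC(=O)Nc1ccc(C(=O)OC)cc1`; in an assay on isolated protein for inhibition of long-chain fatty acid transport protein 1 (Homo sapiens) (a lower number here means a stronger inhibitor, a higher number a weaker inhibitor), compound 1 gives 540 nM.
Compound 2 `CCn1nnc(-c2ccc(NC(=O)CSc3nnc(CNc4ccccc4)n3CC)cc2)n1`; in this assay compound 2 gives > 1000 nM, a limit of the assay and not a number.

Compound 2 thus stands only at the limit of > 1000 nM in this assay, at which 1 of the 2 values shown sits. Compound 3 `CCn1c(CNc2ccccc2)nnc1SCC(=O)Nc1ccc(C(C)=O)cc1` differs from compound 2 by acetyl in place of 2-ethyl-2H-tetrazol-5-yl on an aromatic carbon. Within the data shown here, the one measured step at this position, an at least 1.8-fold higher number from compound 1 to compound 2 (0.26 log units; that floor lies within the scatter), went toward the limit on exchanging methoxycarbonyl for the tetrazolyl group. Acetyl, like methoxycarbonyl, carries a carbonyl. Compound 3 is expected to step back to a measurable number, an at least 1.5-fold lower number from compound 2 to compound 3 (0.18 log units; that floor lies within the scatter), because compound 1 gives 540 nM with its carbonyl substituent. Compound 3 is estimated at 650 nM, range 250 nM to 2000 nM.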

Compound 3, half-maximal inhibitory concentration: > 1000 nM
Compound 3 ended at the assay's limit; the forecaster's own chance of this, stated with the estimate: 30%; middle value at least 1.5-fold (0.18 log units) from the limit.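

A carbonyl on this aromatic carbon does not by itself keep the read-out measurable: methyl in place of methoxy on the carbonyl carbon gives an at least 1.8-fold higher number from compound 1 to compound 3 (0.26 log units; that floor lies within the scatter). In this assay compound 3 gives > 1000 nM, a limit of the assay and not a number, and the step from compound 2 to compound 3 cannot be read. Only compound 1 carries a number so far, and the others stand at one ceiling: the limit of > 1000 nM in this assay, at which 2 of the 3 values shown sit.

From the compounds shown here alone, whether methoxycarbonyl truly differs from acetyl here remains open. Also open, going by these compounds, is whether a carboxylic acid or a primary amide at this place returns a measurable number.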